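Nitrile in Place of Propynyl on a Fused Core

This account rests on a few compounds, and the source may have more. Where it says the series, first, only, none or still open, it means among the compounds named here.

Compound 2 `CC#Cc1cnc2[nH]c(=O)n(C(CC)CC)c2n1` was run in an ADME assay on microsomes from liver (Rattus norvegicus), read by LC-MS, with a stated time of 90 min (on this read-out higher numbers stand for higher hepatic extraction and lower numbers for lower hepatic extraction), but gives "not determined" (no result reported), so no single number places it on this read-out. Among the compounds with values here, the only anchor comes from compound 1 `CCC(CC)n1c(=O)[nH]c2ncc(Cl)nc21`, which shares the core and in this assay gives 0.4. Compound 3 `CCC(CC)n1c(=O)[nH]c2ncc(C#N)nc21` has not yet been measured; it differs from compound 2 in one place: cyano in place of prop-1-yn-1-yl on an aromatic carbon. Within the data shown here, with no measured step between any two compounds of this set, the size of the change cannot be read from the data, and no value is ascribed to the cyano or the prop-1-yn-1-yl group. With compound 1 giving 0.4 as the only measured point on this core, compound 3 is expected to sit somewhat below it, by a step that may not exceed the usual scatter. Compound 3 is therefore estimated at 0.3, within a range of 0.1 to 0.5.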

Compound 3, hepatic extraction ratio: < 0.2
Compound 3 gave a limit, no number; the forecaster's own chance of this, stated with the estimate: 10%; middle value at least 0.10 away from the limit.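

Cyano in place of chloro on this aromatic carbon of the shared core gives the first readable step of the set in this assay, a number at least 0.20 lower from compound 1 to compound 3 (beyond the scatter). This shows that the group on this carbon, next to the ring nitrogen, can shift hepatic extraction beyond the scatter, which compound 1 alone could not show. For compound 3, the value < 0.2 is a limit of the assay and not a number, so the step gives only a minimum size: the limit of < 0.2 in this assay, at which 1 of the 3 values shown sits.

Compound 2 has no reported result and the steps to it cannot be read, which leaves the prop-1-yn-1-yl group unplaced against chloro and cyano. From the compounds shown here alone, whether an amine or a methoxy group on this carbon would read closer to compound 1 or to compound 3 also stays open.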